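Swapping a chloropyridine for a fluorinated chlorophenyl

The compounds below may be only part of what the source reports. "The series", "measured", "known", "first", "only" and "open" are said of these compounds alone.

Of the compounds shown here, three have been measured in an assay on isolated protein for inhibition of thyroid hormone receptor beta (Homo sapiens), read by fluorescence, with a stated time of 30 min; on this read-out lower numbers stand for stronger inhibition and higher numbers for weaker inhibition. Compound 1 `COc1cc(C(=O)NCc2cccc(Cl)c2)cc2nn(CCn3cccn3)cc12` gives 464 nM. Compound 2 `COc1cc(C(=O)N2CCCC2)cc2nc(NCc3cccc(Cl)c3)oc12` gives 180 nM. Compound 3 `COc1cc(C(=O)N2CCC(O)C(C)C2)cc2nc(NCc3cc(Cl)ccn3)oc12` gives 190 nM, the second highest of the three numbers; its number and that of compound 2 lie within the usual scatter of each other, whereas the number for compound 1 is higher by a margin beyond that scatter.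

Compound 4 `COc1cc(C(=O)N2CCC(O)C(C)C2)cc2nc(NCc3cc(Cl)ccc3F)oc12` has not yet been measured. It differs from compound 3 in one place: 5-chloro-2-fluorophenyl in place of 4-chloropyridin-2-yl on a saturated chain carbon bound to a nitrogen on an aromatic ring. Compound 2 already carries a chlorine-bearing benzyl group of this kind on the same nitrogen and gives 180 nM, a number close to that of compound 3. With nothing in these three compounds pointing to a large effect from this exchange, the step from compound 3 to compound 4 is expected to be small, a 1.3-fold lower number from compound 3 to compound 4 (0.10 log units; within the scatter), and not clearly beyond the scatter in either direction. For compound 4 the expected value in this assay is 150 nM, with a likely range from 50 nM to 450 nM.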

Compound 4, half-maximal inhibitory concentration: 300 nM
For compound 4 the middle estimate is 2.0-fold (0.30 log units) below the measured one, within the range that was stated.
By their numbers in this assay, from the lowest: compounds 2, 3, 4 and 1 (each within the scatter of the next, the first and the last beyond it).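

In this assay, among these compounds, this is the first pair of compounds that differ in only one place, and the exchange gives a 1.6-fold higher number from compound 3 to compound 4 (0.20 log units; within the scatter), so no real difference can be claimed. On a saturated chain carbon bound to a nitrogen on an aromatic ring, 5-chloro-2-fluorophenyl therefore serves as well as 4-chloropyridin-2-yl, even though the ring nitrogen, counted as a hydrogen-bond acceptor, is gone and a fluorine has arrived. No separate measurement bears on why the two groups read alike.

This exchange alters the ring nitrogen and the fluorine together, so the compounds shown cannot say what either does alone. Also open, from the compounds shown here alone, is whether a plain phenyl ring, or one carrying an amine or a carboxylic acid, would stay in the same range.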